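One Carbon Further Along the Amide Chain

The source may report more compounds than this note shows. Statements on the series, on what has been measured and on what is new or still open speak of the compounds shown alone.

The three measured compounds were tested in an assay on isolated protein for agonist activity at melatonin receptor type 1C (Xenopus laevis), read by spectrophotometry; a lower number here means a smaller maximal response, a higher number a larger maximal response. Compound 1 `COc1ccc(F)c(CNC(C)=O)c1` gives 100% in this assay. Compound 2 `CCC(=O)NCc1cc(OC)ccc1F` gives 69% in this assay. Compound 3 `CCC(=O)NCCCc1ccc(F)c(OC)c1` gives 89% in this assay, so its maximal response sits between those of the other two.

Compound 1 and compound 2 differ in a single spot. methyl in place of hydrogen on a saturated chain carbon bound to a carbonyl carbon That small addition goes with a step of a number 31 percentage points lower from compound 1 to compound 2 (beyond the scatter). Compound 1 and compound 3 differ in more than one place, and the difference between the two cores is not broken down here.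

Compound 4 `CCCC(=O)NCCCc1ccc(F)c(OC)c1` has not yet been measured. For the measured compounds named here, it differs from compound 3 in one spot. methyl in place of hydrogen on a saturated chain carbon, two bonds along the chain from a carbonyl carbon This is the same kind of change as the one from compound 1 to compound 2, but not the same: the earlier methyl entered on a saturated chain carbon bound to a carbonyl carbon, while here it enters on a saturated chain carbon, two bonds along the chain from a carbonyl carbon.

Going by the values given here, an expected step of a number 17 percentage points lower from compound 3 to compound 4 (beyond the scatter) in this assay rests on compound 1 and compound 2, because a number 31 percentage points lower from compound 1 to compound 2 (beyond the scatter) is the only measured step of this kind, and the added carbon now sits one bond further from the carbonyl, so a somewhat smaller fall is expected. In this assay compound 4 is therefore estimated at 72%, most likely between 52% and 92%.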

Compound 4, largest response reached (reported as efficacy), in percent of the reference or control that the assay uses: 89%
The estimate for compound 4 lay 17 percentage points below the measured number; measured number inside the range.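

Replacing a hydrogen with methyl on a saturated chain carbon, two bonds along the chain from a carbonyl carbon, turns the propanoyl group into propylcarbonyl, and in this assay this gives no change at the digits printed from compound 3 to compound 4 (within the scatter). The large fall seen earlier, when a methyl entered on the core of compound 1, does not reappear, and the two steps stand clearly apart: the same change on two cores in this assay, a number 31 percentage points lower (beyond the scatter) from compound 1 to compound 2 and no change at the digits printed (within the scatter) from compound 3 to compound 4, 31 percentage points apart, beyond the scatter of two such steps This shows that, in this series, the effect of adding one methyl to the amide chain cannot simply be carried from one core to another, but it does not show whether the core or the place of the methyl sets the two steps apart, since they differ in both and each is a single measured step.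

The compounds shown leave open what the propylcarbonyl group would do on the core of compound 1, a comparison that would help separate the core from the place of the methyl. They also leave open how the maximal response would read with a longer chain, such as pentanoyl, or with a cyclopropyl group on the amide carbonyl.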